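The source may hold more compounds than are shown below. What is called first, only, known or untested is meant among the compounds shown, and "the series" means these compounds.

Of the compounds shown here, three have so far been tested in a functional assay on SW480 cells (Homo sapiens) for cytotoxicity, read by MTT assay, with a stated time of 48 h (a lower number here means a stronger inhibitor, a higher number a weaker inhibitor), and none has given an exact number. Compound 1 `Oc1ccc(N[C@H]2CC[C@]3(CC2)OO[C@]2(O3)C3CC4CC(C3)CC2C4)c2cccnc12` reads > 50000 nM, which is a limit of the assay and not a measured value. Compound 2 `Oc1ccc(N[C@H]2CC[C@@]3(CC2)OC[C@]2(OO3)C3CC4CC(C3)CC2C4)c2cccnc12` reads > 50000 nM, again a limit. Compound 3 `O=C(NO)[C@H]1CC[C@@]2(CC1)OC[C@]1(OO2)C2CC3CC(C2)CC1C3` reads > 50000 nM, also a limit. Compound 3 therefore stands where the other two stand, and the whole picture is the limit of > 50000 nM in this assay, at which 3 of the 3 values shown sit.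

Compound 4 `O=C(O)[C@H]1CC[C@@]2(CC1)OC[C@]1(OO2)C2CC3CC(C2)CC1C3` differs from compound 3 in one place: hydroxy in place of hydroxyamino on a carbonyl carbon. In words, hydroxy takes the place of hydroxyamino on a carbonyl carbon, turning hydroxycarbamoyl into carboxy. For the measured compounds named here, no measured pair shows what this change does. With compound 3 at > 50000 nM, a limit, no step beyond the scatter is expected in this assay, in either direction, and a further limit is the likeliest report. The expected step is small, a number no higher from compound 3 to compound 4 (the limit leaves the size open). For compound 4 the estimated value is 50000 nM, with an expected range of 25000 nM to 100000 nM.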

Compound 4, half-maximal inhibitory concentration: > 100000 nM
Compound 4 was reported as a limit (the forecaster's own chance of this, stated with the estimate: 90%); middle value at least 2.0-fold (0.30 log units) away from the limit.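

Compound 3 and compound 4 are both reported in this assay only as limits, and no step can be read between them. Whether turning hydroxycarbamoyl into carboxy changes the result at all stays open, as does the exact strength of all four compounds shown.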